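A few compounds are considered here, and "the series" means these few. Any claim that something is new, unique, unknown or untested is made for them only; others in the source may bear on it.

Three compounds were measured in an assay on Sf9 cells for inhibition of protein deacetylase HDAC6 (Homo sapiens), read by fluorescence, with a stated time of 40 min; a higher number here means a weaker inhibitor, a lower number a stronger inhibitor:

Compound 1, `Cc1ccc(-c2nc(CNc3ccc(C(=O)NO)cc3)n(-c3ccccc3)n2)cc1`: 224 nM
Compound 2, `O=C(NO)c1ccc(NCc2nc(-c3cc4ccccc4s3)nn2-c2ccccc2)cc1`: 324 nM
Compound 3, `O=C(NO)c1ccc(NCc2nc(-c3ccccc3)nn2-c2ccccc2)cc1`: 112 nM

Compound 3 gives the lowest of the three numbers in this assay, but the gap to compound 1, a 2.0-fold lower number from compound 1 to compound 3 (0.30 log units; within the scatter), lies within the scatter, so the two cannot be ranked; only the gap to compound 2, a 2.9-fold lower number from compound 2 to compound 3 (0.46 log units; beyond the scatter), is a real if modest difference.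

Compound 4, `Cc1cccc(-c2nc(CNc3ccc(C(=O)NO)cc3)n(-c3ccccc3)n2)c1`, is compound 3 with methyl in place of hydrogen on an aromatic carbon. For the measured compounds named here, the one measured step of the same kind is the reverse change from compound 1 to compound 3, where the methyl sits at another place on the same ring: a 2.0-fold lower number from compound 1 to compound 3 (0.30 log units; within the scatter). That step stayed within the scatter. On that basis the step from compound 3 to compound 4 in this assay is expected to be small, if anything a slightly higher number, and not beyond the scatter: a 1.5-fold higher number from compound 3 to compound 4 (0.18 log units; within the scatter). Compound 4 is therefore estimated at 170 nM, with a range from 70 nM to 400 nM.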

Compound 4, half-maximal inhibitory concentration: 281 nM
Compound 4: the middle estimate sits 1.7-fold (0.22 log units) below what was measured; the measured number falls inside the stated range.
By their numbers in this assay, from the lowest: compounds 3, 1, 4 and 2 (each within the scatter of the next, the first and the last beyond it).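

In this assay, methyl at this place on the phenyl ring gives a step beyond the scatter, though a modest one (a 2.5-fold higher number from compound 3 to compound 4 (0.40 log units; beyond the scatter)), whereas the same group at the other place on that ring stayed within it. Even so, the two methylphenyl compounds cannot be told apart (a 1.3-fold higher number from compound 1 to compound 4 (0.10 log units; within the scatter)), so this result does not show that the place of the methyl matters. The 3-methylphenyl and 1-benzothiophen-2-yl groups also cannot be separated (a 1.2-fold lower number from compound 2 to compound 4 (0.06 log units; within the scatter)), and nothing available explains any of these steps. The compounds shown leave open whether the change at this place belongs to methyl alone or would also follow from a chlorine, a methoxy group or an amine. They also leave open how a longer chain such as ethyl would compare there.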